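The source may hold more compounds than are shown below. What is called first, only, known or untested is meant among the compounds shown, and "the series" means these compounds.

Measured compounds:
compound 1 `O=C(O)c1ccccc1-c1ccc(CCc2ncc(Cc3ccccc3F)[nH]2)cc1` — 177 nM
compound 2 `CCCCc1cnc(C(CC)Cc2ccc(-c3ccccc3C(=O)O)cc2)[nH]1` — 2720 nM
compound 3 `CC(C)(C)c1cnc(CCc2ccc(-c3ccccc3C(=O)O)cc2)[nH]1` — 4330 nM

In an in vitro functional assay on cells for agonist activity at Bombesin receptor subtype-3 (Homo sapiens), read by luminescence and calcium flux (on this read-out lower numbers stand for an effect already at smaller amounts and higher numbers for an effect only at larger amounts of compound), compound 3 gives the highest of the three numbers, though compound 2, with 2720 nM, sits within the usual scatter of it, so the two cannot be ordered. Compound 1, with 177 nM, lies well apart from both.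

Compound 4 `O=C(O)c1ccccc1-c1ccc(CCc2ncc(CC3CCCC3)[nH]2)cc1` has not yet been measured. It differs from compound 3 in one place: cyclopentylmethyl in place of tert-butyl on an aromatic carbon. For the measured compounds named here, only one measured step touches this position, a 24-fold higher number from compound 1 to compound 3 (1.39 log units; beyond the scatter), which was large and beyond the scatter. The group entering in compound 4 shares with the group of compound 1 a single carbon between the five-membered aromatic ring and a ring, while keeping, like compound 3, a group of carbon only and no aromatic ring. Going by the values given here, a step downward in this assay is therefore expected, smaller than the step from compound 1 to compound 3, since no measured compound shows what a non-aromatic ring at this place does. Compound 4 is estimated to give 900 nM (range 300 nM to 2700 nM), an expected step of a 4.8-fold lower number from compound 3 to compound 4 (0.68 log units; beyond the scatter).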

Compound 4, half-maximal effective concentration: 133 nM
Beside the measured number, compound 4's estimate is 6.8-fold (0.83 log units) above it; the whole stated range lies above it.
By their numbers in this assay, from the lowest: compounds 4 and 1 (each within the scatter of the next); then compounds 2 and 3 (each within the scatter of the next).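

In this assay, for the compounds shown here, cyclopentylmethyl in place of tert-butyl on this aromatic carbon gives a 33-fold lower number from compound 3 to compound 4 (1.51 log units; beyond the scatter) and so shows that the large loss seen with tert-butyl does not extend to every group of carbon only that lacks an aromatic ring. Nor does the number of compound 1 depend on an aromatic ring in this group: cyclopentyl in place of 2-fluorophenyl gives a 1.3-fold lower number from compound 1 to compound 4 (0.12 log units; within the scatter) and leaves the two compounds impossible to order. Nothing available explains why tert-butyl and cyclopentylmethyl differ so widely.

The compounds shown leave open whether the ring of the entering group matters at all or whether the saturated chain carbon bound to the aromatic carbon is enough, a question that isobutyl at this place would address. They also leave open what a ring containing nitrogen, as in piperidin-4-ylmethyl, would do here.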